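From trifluoromethoxy to cyano on a shared core

A few compounds are considered here, and "the series" means these few. Any claim that something is new, unique, unknown or untested is made for them only; others in the source may bear on it.

Compound 1 `CC(C)c1cccc(NC(=O)CCc2cccc3c2B(O)OC3)c1` gives 510 nM
Compound 2 `O=C(CCc1cccc2c1B(O)OC2)Nc1cccc(-c2cccc(OC(F)(F)F)c2)c1` gives 460 nM

In a functional assay on SK-OV-3 cells (Homo sapiens) for antiproliferative activity, read by MTT assay, with a stated time of 72 h (a higher number here means a weaker inhibitor, a lower number a stronger inhibitor), compound 2 stands level with compound 1, the two values lying within the usual scatter of repeated measurements. Compound 3 `N#Cc1cccc(-c2cccc(NC(=O)CCc3cccc4c3B(O)OC4)c2)c1` differs from compound 2 in one place: cyano in place of trifluoromethoxy on an aromatic carbon. Within the data shown here, no measured pair shows this swap directly. Still, compound 1 at 510 nM and compound 2 at 460 nM carry different groups on the shared core and remain within the scatter, so no clear direction is expected. The estimated step of a 1.3-fold lower number from compound 2 to compound 3 (0.12 log units; within the scatter) stays within the scatter in this assay as well. For compound 3 the expected value is 350 nM (estimated range 120 nM to 1000 nM).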

Compound 3, half-maximal inhibitory concentration: 120 nM
Estimate against measurement, compound 3: 2.9-fold (0.46 log units) above, and the stated range covers the measured number.
By their numbers in this assay, from the lowest: compound 3; then compounds 2 and 1 (each within the scatter of the next).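

In this assay this position proves able to shift the number: cyano in place of trifluoromethoxy on an aromatic carbon gives a 3.8-fold lower number from compound 2 to compound 3 (0.58 log units; beyond the scatter) and so moves beyond the scatter, which compound 1 and compound 2 did not do against each other. 3-Cyanophenyl in place of isopropyl on an aromatic carbon gives a 4.3-fold lower number from compound 1 to compound 3 (0.63 log units; beyond the scatter) in the same direction. Nothing available here explains why cyano gives the lower number.

The compounds shown leave open how an amine, a carboxylic acid or a longer chain on this same aromatic carbon would compare with cyano.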